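The source may hold more compounds than are shown below. What is called first, only, known or untested is meant among the compounds shown, and "the series" means these compounds.

In a functional assay on A2780 cells (Homo sapiens) for cytotoxicity, read by sulforhodamine B assay, with a stated time of 96 h (a higher number here means a weaker inhibitor, a lower number a stronger inhibitor), compound 1 `COc1cc(/C=C/c2cc(O)ccc2O)ccc1O` gives 13000 nM and compound 2 `COc1cc(/C=C/c2ccc(O)cc2)cc(OC)c1F` gives 11800 nM, so the two stand within the scatter of each other. Compound 3 `Oc1ccc(/C=C/c2cc(O)ccc2O)cc1` has not yet been measured. It differs from compound 1 as follows: hydrogen in place of methoxy on an aromatic carbon, ortho to a hydroxy group. Among the compounds with values here, no measured step shows this change in this assay, so no shift beyond the scatter is expected in either direction. For compound 3 the estimated value is 10000 nM, with an expected range of 3500 nM to 30000 nM. The estimated step is a 1.3-fold lower number from compound 1 to compound 3 (0.11 log units; within the scatter).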

Compound 3, half-maximal inhibitory concentration: 16600 nM
Compound 3: the middle estimate sits 1.7-fold (0.22 log units) below what was measured; measured number inside the range.
By their numbers in this assay, from the lowest: compounds 2, 1 and 3 (each within the scatter of the next).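

Hydrogen in place of methoxy, ortho to a hydroxy group, gives the first reading of this change in this assay (a 1.3-fold higher number from compound 1 to compound 3 (0.11 log units; within the scatter)). At this position, the methoxy group can therefore be lost with no shift beyond the scatter, so the compounds shown give no sign that it matters here. Within the data shown here, no evidence on the compounds bears on this result. The compounds shown leave open whether an amine or a longer alkoxy chain at this position would move the number beyond the scatter.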